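Methylating a Phenol on Two Different Flavonol Cores

The source may hold more compounds than are shown below. What is called first, only, known or untested is meant among the compounds shown, and "the series" means these compounds.

Of the compounds shown here, three have so far been tested in a functional assay on HT-29 cells (Homo sapiens) for cytotoxicity, read by XTT assay, with a stated time of 72 h; on this read-out higher numbers stand for weaker inhibition and lower numbers for stronger inhibition. Compound 1 `C=C1CC[C@H]2C(C)(C)CCC[C@]2(C)[C@H]1CC/C(C)=C/COc1cc(O)c2c(=O)c(O)c(-c3ccc(OC)cc3)oc2c1` gives > 100000 nM, which is a limit of the assay rather than a number. Compound 3 `C=C1CC[C@H]2C(C)(C)CCC[C@]2(C)[C@H]1CC/C(C)=C/COc1cc(O)c2c(=O)c(O)c(-c3ccc(O)cc3)oc2c1` gives > 100000 nM, again a limit. Within the data shown here, compound 2 `C=C1CC[C@H]2C(C)(C)CCC[C@]2(C)[C@H]1CC/C(C)=C/COc1c(-c2ccc(O)cc2)oc2cc(O)cc(O)c2c1=O` gives 30000 nM, the only number among the three. Compound 1 differs from compound 3 by methyl in place of hydrogen on an oxygen on an aromatic ring, and this step, a step that the two limits leave unreadable from compound 3 to compound 1, cannot be sized because of the limit of > 100000 nM in this assay, at which 2 of the 3 values shown sit. Compound 4 `C=C1CC[C@H]2C(C)(C)CCC[C@]2(C)[C@H]1CC/C(C)=C/COc1c(-c2ccc(OC)cc2)oc2cc(O)cc(O)c2c1=O` has not yet been measured; it differs from compound 2 by methyl in place of hydrogen on an oxygen on an aromatic ring, the same change made on another core. The difference between the core of compound 2 and the core of compound 3 is not broken down here. Among the measured compounds shown here, the only measured instance of this change gives no readable size, so the expectation is simply that compound 4 stays close to compound 2. This expectation rests on compound 2 at 30000 nM and on the unreadable a step that the two limits leave unreadable from compound 3 to compound 1. The step expected is therefore near zero, no change at the digits printed from compound 2 to compound 4 (within the scatter), with a wide range. In this assay compound 4 is expected to give 30000 nM, somewhere between 8000 nM and 100000 nM.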

Compound 4, half-maximal inhibitory concentration: 32000 nM
Compound 4: the middle estimate sits 1.1-fold (0.03 log units) below what was measured, within the range that was stated.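

In this assay, replacing hydrogen with methyl on the oxygen of the aromatic ring, which turns 4-hydroxyphenyl into 4-methoxyphenyl, gives a 1.1-fold higher number from compound 2 to compound 4 (0.03 log units; within the scatter), so on this core the two compounds cannot be told apart. The same change on the other core, from compound 3 to compound 1, cannot be read, as neither value there is a number but a limit of the assay: the limit of > 100000 nM in this assay, at which 2 of the 4 values shown sit. This leaves a single readable step, which shows that the change is tolerated on the core of compound 2 but not that it would have the same size on the core of compound 3.

The compounds shown leave open whether anything other than methyl on that oxygen would behave the same way, for example a longer chain such as propyl or a group carrying a carboxylic acid or an amine. They also leave open whether a step of readable size can be found for this change on the core of compound 3.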